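Fluorine Enters the Phenyl of Compound 2: An Expected Value

The compounds below may be only part of what the source reports. "The series", "measured", "known", "first", "only" and "open" are said of these compounds alone.

Compound 2 `c1ccc(-c2n[nH]cc2N2CCNCC2)cc1` gives the lowest of the three numbers in an assay on isolated protein for binding affinity to 5-hydroxytryptamine receptor 6 (Homo sapiens) (on this read-out higher numbers stand for weaker inhibition and lower numbers for stronger inhibition), at 185 nM. Its nearest neighbour is compound 1 `COc1ccc(-c2n[nH]cc2N2CCNCC2)cc1`, which in this assay gives 279 nM; the step of a 1.5-fold lower number from compound 1 to compound 2 (0.18 log units; within the scatter) lies within the scatter, so these two cannot be ordered. Compound 3 `Fc1ccccc1-c1n[nH]cc1N1CCNCC1` gives 713 nM in this assay, and the step of a 3.9-fold higher number from compound 2 to compound 3 (0.59 log units; beyond the scatter) is beyond the scatter.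

Compound 4 `Fc1ccc(-c2n[nH]cc2N2CCNCC2)cc1` differs from compound 2 by fluoro in place of hydrogen on an aromatic carbon. Going by the values given here, two measured steps bear on this. The step from compound 2 to compound 3 also adds fluorine to the same ring, though at a different place, and was a 3.9-fold higher number from compound 2 to compound 3 (0.59 log units; beyond the scatter). The step from compound 1 to compound 2 removed methoxy from the very place that fluorine now enters, and was a 1.5-fold lower number from compound 1 to compound 2 (0.18 log units; within the scatter). A group at this place changed little, while fluorine elsewhere on the ring cost a modest amount; the expected step is therefore small, weaker if anything: a 1.4-fold higher number from compound 2 to compound 4 (0.13 log units; within the scatter). Compound 4 is estimated at 250 nM in this assay, with a range from 120 nM to 520 nM.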

Compound 4, inhibition constant: 373 nM
Estimate against measurement, compound 4: 1.5-fold (0.17 log units) below; the range from low to high includes it.
By their numbers in this assay, from the lowest: compounds 2, 1, 4 and 3 (each within the scatter of the next, the first and the last beyond it).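

At the place para to a large group, the ring now carries three different substituents across compounds 1, 2 and 4, and none of them can be told apart in this assay: fluoro in place of hydrogen gives (a 2.0-fold higher number from compound 2 to compound 4 (0.30 log units; within the scatter)), and fluoro in place of methoxy gives (a 1.3-fold higher number from compound 1 to compound 4 (0.13 log units; within the scatter)). So this position, unlike the fluorinated place in compound 3, shows no step beyond the scatter for either of the two groups tried there, a small atom and a larger ether alike. Nothing measured here explains why the two fluorine placements on this ring read differently from compound 2.

On these data alone, whether a carboxylic acid, an amine or a longer chain at this place would shift the number beyond the scatter remains open. So does whether chloro would behave as fluoro does here.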